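Notes on the step from compound 2 to compound 4

The compounds below may be only part of what the source reports. "The series", "measured", "known", "first", "only" and "open" are said of these compounds alone.

Values in a functional assay on the whole organism (strain Swiss CD-1) with Mus musculus as the target, with a stated time of 2 h; on this read-out lower numbers stand for an effect already at smaller amounts and higher numbers for an effect only at larger amounts of compound:
- compound 1 `COCC(C(=O)N1CCN(c2cccc(Cl)c2Cl)CC1)N1C(=O)CCC1=O`: 38 mg/kg
- compound 2 `COCC(C(=O)N1CCN(c2cccc(C)c2)CC1)N1C(=O)CCC1=O`: 47.7 mg/kg
- compound 3 `COC[C@@H](C(=O)N1CCN(c2ccc(C(F)(F)F)cc2)CC1)N1C(=O)CCC1=O`: 37.9 mg/kg
- compound 4 `COCC(C(=O)N1CCN(C)CC1)N1C(=O)CCC1=O`: not yet measured

Compound 2, at 47.7 mg/kg, lies within the scatter of both compound 1 and compound 3, so no order can be read among the three. Compound 4 differs from it by one change: methyl in place of 3-methylphenyl on an amine nitrogen in a ring. In words, this is methyl in place of 3-methylphenyl on an amine nitrogen in a ring.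

Within the data shown here, one measured step bears on this: a 1.3-fold higher number from compound 1 to compound 2 (0.10 log units; within the scatter), with 3-methylphenyl in place of 2,3-dichlorophenyl. That exchange keeps an aromatic ring at this nitrogen, as does compound 3, and it stays within the scatter. Among the measured compounds shown here, no measured compound lacks the aromatic ring there, so the series offers no direct guide to its removal, and any figure is an extrapolation with wide margins. A step beyond the scatter, towards a higher number in this assay, is nevertheless the working expectation. The expected change is a 2.1-fold higher number from compound 2 to compound 4 (0.32 log units; beyond the scatter). For compound 4 the estimated value is 100 mg/kg, with an expected range of 40 mg/kg to 250 mg/kg.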

Compound 4, dose for half-maximal effect: 68.2 mg/kg
For compound 4 the middle estimate is 1.5-fold (0.17 log units) above the measured one; the range from low to high includes it.
By their numbers in this assay, from the lowest: compounds 3, 1, 2 and 4 (each within the scatter of the next).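

In this assay, the methyl of compound 4 gives a 1.4-fold higher number from compound 2 to compound 4 (0.16 log units; within the scatter) and a 1.8-fold higher number from compound 1 to compound 4 (0.25 log units; within the scatter), so neither exchange at this position separates compound 4 from the compound carrying an aromatic ring. The earlier compounds shown here kept an aromatic ring on this amine nitrogen and so could show only exchanges among aryl groups; here a group of 7 heavy atoms with one six-membered aromatic ring leaves, 1 heavy atom enters, and the read-out stays within the scatter of both compounds. In this series, therefore, the aromatic ring at this nitrogen is not needed for a half-maximal effect at doses of this order, and no available data explain this result.

Open, as far as these compounds go, is how this nitrogen behaves with a hydrogen, a longer alkyl chain such as butyl, or a benzyl group, any of which would test the flat picture given by methyl and the aryl groups. Also open, from the compounds shown here alone, is whether the same insensitivity holds when the rest of the core changes, for example with an amine or a carboxylic acid elsewhere on the shared core.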